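A Nitro Group Added to Two Related Cores

The compounds below may be only part of what the source reports. "The series", "measured", "known", "first", "only" and "open" are said of these compounds alone.

Of the compounds shown here, three have been measured in a functional assay on KB cells (Homo sapiens) for cytotoxicity, read by MTT assay, with a stated time of 48 h; a higher number here means a weaker inhibitor, a lower number a stronger inhibitor. Compound 1 `CCn1cc(-c2nc3ccccc3o2)c(=O)c2cc(F)c(Cl)cc21` gives 10200 nM in this assay. Compound 3 `CCn1cc(-c2nc3ccc([N+](=O)[O-])cc3o2)c(=O)c2cc(F)c(Cl)cc21` differs from compound 1 by one change, (nitro in place of hydrogen on an aromatic carbon); in this assay compound 3 gives 500 nM. That single change made a large step, a 20-fold lower number from compound 1 to compound 3 (1.31 log units; beyond the scatter). Compound 2 `CCn1cc(-c2nc3ccccc3o2)c(=O)c2cc(F)c(N3CCNC(C)C3)c(F)c21` has a different core; the difference between the core of compound 1 and the core of compound 2 is not broken down here. In this assay compound 2 gives 18900 nM, a value within the scatter of the value of compound 1, so the two cannot be ranked against each other.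

Compound 4 `CCn1cc(-c2nc3ccc([N+](=O)[O-])cc3o2)c(=O)c2cc(F)c(N3CCNC(C)C3)c(F)c21` is compound 2 with the same change that led from compound 1 to compound 3, (nitro in place of hydrogen on an aromatic carbon); the change occurs twice among these compounds, at the same place each time. Because the earlier step was a 20-fold lower number from compound 1 to compound 3 (1.31 log units; beyond the scatter), the step from compound 2 to compound 4 is expected to be of similar size, a 16-fold lower number from compound 2 to compound 4 (1.20 log units; beyond the scatter), with some allowance for the different core of compound 2. Compound 4 is therefore estimated at 1200 nM, expected to fall between 300 nM and 6000 nM.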

Compound 4, half-maximal inhibitory concentration: 600 nM
Compound 4: the middle estimate sits 2.0-fold (0.30 log units) above what was measured; low and high end bracket the measured number.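

In this assay, nitro in place of hydrogen on an aromatic carbon again made a large step, a 32-fold lower number from compound 2 to compound 4 (1.50 log units; beyond the scatter). Set beside the earlier step, the new one cannot be told apart from it in size, so on these two cores the change carried over with much the same effect: the same change on two cores in this assay, a 20-fold lower number (1.31 log units; beyond the scatter) from compound 1 to compound 3 and a 32-fold lower number (1.50 log units; beyond the scatter) from compound 2 to compound 4, 1.5-fold (0.19 log units) apart, within the scatter of two such steps. Among these compounds, this rests on only two pairs of compounds, with the nitro at the same place each time, so it says nothing about how the change would behave on a third core, and nothing about why the number falls.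

The compounds shown leave open whether another group at that same place, such as an amine or a carboxylic acid, would lower the number as far as nitro does. They also leave open whether a nitro elsewhere on that six-membered ring of carbon would give a step of similar size.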